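A few compounds are considered here, and "the series" means these few. Any claim that something is new, unique, unknown or untested is made for them only; others in the source may bear on it.

Compound 1, `CC1=C(CCC(=O)OCCCCOc2no[n+]([O-])c2S(=O)(=O)c2ccccc2)C(=O)c2c(O)cccc2C1=O`, was tested in a functional assay on HepG2 cells (Homo sapiens) for inhibition, read by MTT assay, with a stated time of 72 h, tested at 10 uM (a lower number here means less inhibition of growth, a higher number more inhibition of growth at the concentration tested), and gave 95.4%. Compound 2, `CC1=C(C(C)CC(=O)OCCCCOc2no[n+]([O-])c2S(=O)(=O)c2ccccc2)C(=O)c2c(O)cccc2C1=O`, gave 89.2% in this assay. The two differ by methyl in place of hydrogen on a saturated chain carbon bound to a double-bonded ring carbon and a saturated chain carbon, and this change made a step of a number 6.2 percentage points lower from compound 1 to compound 2 (within the scatter). Compound 3, `CC1=C(CCC(=O)OCCCOc2no[n+]([O-])c2S(=O)(=O)c2ccccc2)C(=O)c2c(O)cccc2C1=O`, gave 95.1% in this assay; how its core differs from that of compound 1 is not broken down here. Compound 4, `CC1=C(CCC(=O)OCC(C)COc2no[n+]([O-])c2S(=O)(=O)c2ccccc2)C(=O)c2c(O)cccc2C1=O`, has not yet been measured in this assay. It differs from compound 3 by methyl in place of hydrogen on a saturated chain carbon bound to two saturated chain carbons. Among these compounds this change occurs twice, and the change here is the same kind as that from compound 1 to compound 2, though the place is not the same: there the carbon carrying the new methyl is bound to a double-bonded ring carbon and a saturated chain carbon, here it is bound to two saturated chain carbons. Among the compounds with values here, with only that one earlier instance to go on, the step is expected to be a number 4.1 percentage points lower from compound 3 to compound 4 (within the scatter), small like a number 6.2 percentage points lower from compound 1 to compound 2 (within the scatter). Compound 4 is therefore estimated to give 91% in this assay, with a likely range from 82% to 97%.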

Compound 4, percent growth inhibition at one concentration: 73.4%
Compound 4: middle estimate off by 17.6 percentage points, on the high side; the whole stated range lies above it.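

In this assay the methyl in place of hydrogen gives a number 21.7 percentage points lower from compound 3 to compound 4 (beyond the scatter) on this core, and the size of the earlier step cannot be carried over to it: the same change on two cores in this assay, a number 6.2 percentage points lower (within the scatter) from compound 1 to compound 2 and a number 21.7 percentage points lower (beyond the scatter) from compound 3 to compound 4, 15.5 percentage points apart, beyond the scatter of two such steps. The change is the same in kind but not in place, since the carbon carrying the new methyl is bound to a double-bonded ring carbon and a saturated chain carbon in compound 2 and to two saturated chain carbons in compound 4, and these two pairs cannot separate the part played by the place from the part played by the core. Within the data shown here, two instances show only that the step can differ; they give no rule for its size and no cause for the gap.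

The compounds shown leave open how an ethyl group or a hydroxyl group on that same saturated chain carbon would read in this assay. They also leave open whether the methyl would give a similar step on a chain longer than that of compound 1.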